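Dithiane in place of acetylethyl on the lactone core

The compounds below may be only part of what the source reports. "The series", "measured", "known", "first", "only" and "open" are said of these compounds alone.

Compound 1 `CC(=O)O[C@@H]1OC(=O)[C@](C)(C(C)=O)[C@@H]1C` and compound 2 `CC(=O)CC[C@]1(C(C)=O)C(=O)O[C@@H](OC(C)=O)[C@H]1C` are the measured members. In a functional assay on MCF7 cells (Homo sapiens) for cytotoxicity, read by MTT assay (a higher number here means a weaker inhibitor, a lower number a stronger inhibitor), compound 1 gives 6000 nM; in this assay compound 2 gives 6000 nM, and the step of no change at the digits printed from compound 1 to compound 2 (within the scatter), 2-oxopropyl in place of hydrogen on a saturated chain carbon, stays within the scatter. Compound 2 thus stands level with compound 1 at the digits shown. Compound 3 `CC(=O)O[C@@H]1OC(=O)[C@@](C(C)=O)(C2SCCCS2)[C@@H]1C` carries the change (a group of 6 heavy atoms (4 carbon, 2 sulfur; one six-membered non-aromatic ring with 2 hetero atoms) in place of a group of 5 heavy atoms (4 carbon, 1 oxygen; no ring), on a saturated ring carbon). Among the measured compounds shown here, only the indifferent step from compound 1 to compound 2 bears on this; no measured step exchanges a chain for a ring, so no step beyond the scatter is expected. Compound 3 is estimated at 6000 nM, range 2000 nM to 20000 nM, with the step of no change at the digits printed from compound 2 to compound 3 (within the scatter) expected to remain within the scatter.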

Compound 3, half-maximal inhibitory concentration: > 50000 nM
Compound 3 was reported as a limit; the forecaster's own chance of this, stated with the estimate: 10%; middle value at least 8.3-fold (0.92 log units) away from the limit.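

Methyl and 2-acetylethyl on this saturated ring carbon read alike, so the earlier compounds showed this position tolerating a change. The six-membered non-aromatic ring with 2 hetero atoms does not fit that picture, giving an at least 8.3-fold higher number from compound 2 to compound 3 (0.92 log units; beyond the scatter) and an at least 8.3-fold higher number from compound 1 to compound 3 (0.92 log units; beyond the scatter). For compound 3 the reading is a limit and not a number: the limit of > 50000 nM in this assay, at which 1 of the 3 values shown sits.

Whether the ring or the sulfur atoms account for the step stays open, and so does its true size. A 1,3-dioxane ring or an open bis(methylthio)methyl group at this carbon would separate the two.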